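The source may report more compounds than this note shows. Statements on the series, on what has been measured and on what is new or still open speak of the compounds shown alone.

Measured so far:
compound 1 `C/N=C(/NC)Nc1nc(-c2ccc(OC)cc2)c(-c2ccc(OC)cc2)s1` — in a functional assay with Oryctolagus cuniculus as the target (a lower number here means a stronger inhibitor, a higher number a weaker inhibitor), compound 1 gives 970 nM
compound 2 `CCOC(=O)/C=C/c1nc(-c2ccc(OC)cc2)c(-c2ccc(OC)cc2)s1` — in this assay compound 2 gives 20 nM

Going by the values given here, compound 1 stands with the highest of the two numbers; its only neighbour is compound 2, reached by a 49-fold lower number from compound 1 to compound 2 (1.69 log units; beyond the scatter). Compound 3 `COc1ccc(-c2nc(C3=NNC(=O)CC3)sc2-c2ccc(OC)cc2)cc1` is not yet measured. Its change from compound 1 is a group of 7 heavy atoms (4 carbon, 2 nitrogen, 1 oxygen; one six-membered non-aromatic ring with 2 hetero atoms) in place of a group of 6 heavy atoms (3 carbon, 3 nitrogen; no ring), on an aromatic carbon. Among the compounds with values here, only the step from compound 1 to compound 2 bears on this place, where the same departing group was exchanged and the number fell sharply. The entering group differs, so a smaller step is expected. For compound 3 in this assay the estimated step is a 16-fold lower number from compound 1 to compound 3 (1.21 log units; beyond the scatter). Compound 3 is expected to give 60 nM, between 8 nM and 400 nM.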

Compound 3, half-maximal inhibitory concentration: > 1000 nM
Compound 3: only a limit was reported; the forecaster's own chance of this, stated with the estimate: 0%; at least 16-fold (1.22 log units) between middle value and limit.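

In this assay compound 3 is reported only as a limit, > 1000 nM. At this aromatic carbon, then, replacing the group of compound 1 does not by itself lower the number, as the six-membered ring with 2 hetero atoms falls well short of the open chain of compound 2: an at least 50-fold higher number from compound 2 to compound 3 (1.69 log units; beyond the scatter). Against the starting group the comparison gives only a floor, an at least 1.0-fold higher number from compound 1 to compound 3 (0.01 log units; that floor lies within the scatter), so no order between those two groups can be read. On these data alone, whether a carboxylic acid in place of the ethyl ester would keep the low number of compound 2 stays open, as does the effect of an amine on the same chain.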